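Chloro for methoxy on the aryl ring across two cores

The compounds below may be only part of what the source reports. "The series", "measured", "known", "first", "only" and "open" are said of these compounds alone.

Measured in a functional assay on CHO cells for agonist activity at Alpha-1A adrenergic receptor (Homo sapiens), read by FLIPR and calcium flux; on this read-out lower numbers stand for an effect already at smaller amounts and higher numbers for an effect only at larger amounts of compound:
compound 1, `COc1cccc(C2CCc3nc[nH]c3C2)c1`, 1050 nM
compound 2, `COc1ccc(C2Cc3nccn3C2)cc1`, 939 nM
compound 3, `Clc1ccc(C2Cc3nccn3C2)cc1`, 3460 nM

Compound 1 and compound 2 sit within the scatter of one another in this assay; the difference between their two cores is not broken down here. From compound 2 to compound 3 the change is chloro in place of methoxy on an aromatic carbon, and the outcome is a 3.7-fold higher number from compound 2 to compound 3 (0.57 log units; beyond the scatter).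

Compound 4, `Clc1cccc(C2CCc3nc[nH]c3C2)c1`, is not yet measured. It differs from compound 1 by chloro in place of methoxy on an aromatic carbon. This is the same kind of change as that from compound 2 to compound 3, not the same: in compound 3 the chloro is para to a group of 8 heavy atoms, in compound 4 meta to a group of 9 heavy atoms, on a different core. Compound 4 is expected to show a step of similar size, a 3.5-fold higher number from compound 1 to compound 4 (0.55 log units; beyond the scatter). Within the data shown here, that expectation rests on the single measured instance of this kind of change, a 3.7-fold higher number from compound 2 to compound 3 (0.57 log units; beyond the scatter). For compound 4 in this assay the estimate is 3700 nM, with a range from 1500 nM to 9000 nM.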

Compound 4, half-maximal effective concentration in the Alpha-1A adrenergic receptor assay: 514 nM
Compound 4: the middle estimate sits 7.2-fold (0.86 log units) above what was measured; measured number outside the range, below it.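

In the Alpha-1A adrenergic receptor assay the exchange of methoxy for chloro gives a 2.0-fold lower number from compound 1 to compound 4 (0.31 log units; beyond the scatter), so the step measured on one core does not carry over to the other in size or direction: the same change on two cores in the Alpha-1A adrenergic receptor assay, a 3.7-fold higher number (0.57 log units; beyond the scatter) from compound 2 to compound 3 and a 2.0-fold lower number (0.31 log units; beyond the scatter) from compound 1 to compound 4, 7.5-fold (0.88 log units) apart, beyond the scatter of two such steps

In a physicochemical assay for lipophilicity, at pH 7.4 (a higher number here means a more lipophilic compound, a lower number a more polar compound), compound 1 gives 2.6 and compound 4 gives 3.3. On the core of compound 1 the same exchange also raises lipophilicity: the measured distribution coefficient of compound 1, 2.6, and of compound 4, 3.3, a number 0.70 log units higher (beyond the scatter)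

The two pairs differ both in the core and in where the group sits on the aromatic ring, so these data do not show which of the two sets the direction of the step, and one pair per core gives no general rule.

Open, going by these compounds, is how fluoro or a nitrile in place of chloro would behave on the core of compound 1 and on the core of compound 2. Also open, on these data alone, is whether an amine or a carboxylic acid on the aromatic ring would be tolerated on either core.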